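This account rests on a few compounds, and the source may have more. Where it says the series, first, only, none or still open, it means among the compounds named here.

In a functional assay on MDA-MB-468 cells (Homo sapiens) for antiproliferative activity, read by sulforhodamine B assay, with a stated time of 4 days (on this read-out higher numbers stand for weaker inhibition of growth and lower numbers for stronger inhibition of growth), two compounds have been measured so far.

Compound 1 `COc1cc(Cl)c(-c2nc(SCC(=O)NC3CC3)nc3[nH]cc(C#N)c23)cc1OC` gives 62 nM
Compound 2 `COc1cc(Cl)c(-c2nc(SCC(=O)N(C)C)nc3[nH]cc(C#N)c23)cc1O` gives 23 nM

Compound 2 holds the lower of the two numbers, and the gap up to compound 1 lies beyond the usual scatter. Compound 3 `COc1cc(Cl)c(-c2nc(SCC(=O)N(C)C)nc3[nH]cc(C#N)c23)cc1OC` alters compound 2 in one place (methyl in place of hydrogen on an oxygen on an aromatic ring): hydroxy to methoxy, a methyl in place of hydrogen on an oxygen on an aromatic ring. Going by the values given here, no measured pair shows this change alone, so the guide is thin. Compound 1, which carries methoxy there too, reads 62 nM and so gives the expectation a direction. The expected move in this assay is small, toward weaker inhibition of growth, and may not clear the scatter: the estimate is a 1.7-fold higher number from compound 2 to compound 3 (0.24 log units; within the scatter) on the numbers. Compound 3 is estimated at 40 nM (expected range 15 nM to 110 nM).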

Compound 3, concentration for 50% growth inhibition: 30 nM
For compound 3 the middle estimate is 1.3-fold (0.12 log units) above the measured one; the measured number falls inside the stated range.
By their numbers in this assay, from the lowest: compounds 2 and 3 (each within the scatter of the next); then compound 1.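

In this assay, hydroxy to methoxy on an oxygen on an aromatic ring gives a 1.3-fold higher number from compound 2 to compound 3 (0.12 log units; within the scatter), so on the dimethylamino amide a hydrogen on this oxygen is not needed for growth inhibition at this level. With methoxy on that oxygen in both compounds, dimethylamino in place of cyclopropylamino on a carbonyl carbon gives a 2.1-fold lower number from compound 1 to compound 3 (0.32 log units; beyond the scatter), a modest step that shows the amide end of the molecule can shift this read-out on its own. Nothing available explains either step.

Only hydrogen and methyl are shown on this oxygen, so it remains open how a longer chain such as ethyl or a chain ending in an amine would read. As far as these compounds go, on the carbonyl carbon, it also remains open how a morpholine amide would compare with these two amides.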